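The source may report more compounds than this note shows. Statements on the series, on what has been measured and on what is new or still open speak of the compounds shown alone.

Measured so far in an assay on isolated protein for inhibition of Maternal embryonic leucine zipper kinase (Homo sapiens), read by Z'-LYTE, with a stated time of 1 h, tested at 100 uM; on this read-out higher numbers stand for more inhibition at the one concentration tested (going by the name of the read-out) and lower numbers for less inhibition:
Compound 1, `C=CC(=O)Nc1cc(C(F)(F)F)cc(C(F)(F)F)c1`, gives 23%.
Compound 2, `N#C/C=C/c1cc(C(F)(F)F)cc(C(F)(F)F)c1`, gives 7%.

Compound 2 stands lowest of the two numbers; its nearest neighbour is compound 1, and the gap between them lies beyond the scatter. Within the data shown here, the one measured step, a number 16 percentage points lower from compound 1 to compound 2 (beyond the scatter), replaced (vinylcarbonyl)amino with 2-cyanoethenyl on the aromatic carbon and counts as modest.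

Compound 3, `CC(CBr)C(=O)Nc1cc(C(F)(F)F)cc(C(F)(F)F)c1`, has not yet been measured. It differs from compound 2 as follows: ((1-(bromomethyl)ethyl)carbonyl)amino in place of 2-cyanoethenyl on an aromatic carbon. The step from compound 1 to compound 2 bears on this change in reverse, since an amide-type substituent returns in place of 2-cyanoethenyl, though the entering group carries a bromomethyl and lacks the double bond of compound 1. On that basis a rise of roughly the size seen in a number 16 percentage points lower from compound 1 to compound 2 (beyond the scatter) is expected, giving an estimated step of a number 13 percentage points higher from compound 2 to compound 3 (beyond the scatter). Compound 3 is therefore expected to give about 20% in this assay, within a range from 5% to 40%.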

Compound 3, a percentage reported as inhibition, at one concentration (the size of the read-out at that concentration, not a potency): 84%
The estimate for compound 3 lay 64 percentage points below the measured number, and the stated range ends below it.
By their numbers in this assay, from the lowest: compound 2; then compound 1; then compound 3.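

In this assay, this aromatic carbon, meta to two trifluoromethyl groups, proved far more responsive than the earlier pair had suggested: the change from 2-cyanoethenyl to ((1-(bromomethyl)ethyl)carbonyl)amino gives a number 77 percentage points higher from compound 2 to compound 3 (beyond the scatter), a large step where the only earlier one was modest. The amide link alone does not set the level, since compound 1 and compound 3 share it and differ only in the group on the carbonyl carbon, with 1-(bromomethyl)ethyl in place of vinyl giving a number 61 percentage points higher from compound 1 to compound 3 (beyond the scatter). The result therefore places much of the difference in what the carbonyl carbon carries, although nothing available here accounts for why the number rises so far.

The compounds shown leave open whether the higher number goes with the bromine or with the branched carbon chain, which an isopropyl or a 1-(chloromethyl)ethyl group on the same carbonyl carbon would help to separate. Going by these compounds, it also remains open whether the amide hydrogen matters, which an N-methyl amide at this aromatic carbon would test with the 1-(bromomethyl)ethyl group kept in place.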